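Swapping the ring of compound 3 for an open chain

The compounds below may be only part of what the source reports. "The series", "measured", "known", "first", "only" and "open" are said of these compounds alone.

Measured in an ADME assay on microsomes from liver (Mus musculus) for metabolic stability (on this read-out higher numbers stand for a longer-lived compound and lower numbers for a shorter-lived compound), so far:
- Compound 1 (`CC(C)C(Cc1ncc[nH]1)c1ccc(-c2ccc3cccc(F)c3c2)[nH]c1=O`) gives < 0.0667 h as a limit
- Compound 2 (`CC(C)C(c1nnc[nH]1)c1ccc(-c2ccc3cccc(F)c3c2)[nH]c1=O`) gives 0.213 h as a number
- Compound 3 (`CC(C)C(c1noc(=O)[nH]1)c1ccc(-c2ccc3cccc(F)c3c2)[nH]c1=O`) gives > 3 h as a limit

Compound 3 has the longest half-life of the three, though its value is only a limit. Compound 4 (`CC(C)NC(=O)CC(c1ccc(-c2ccc3cccc(F)c3c2)[nH]c1=O)C(C)C`) carries (isopropylcarbamoyl)methyl in place of the ring of compound 3 (a group of 7 heavy atoms (5 carbon, 1 nitrogen, 1 oxygen; no ring) in place of a group of 6 heavy atoms (2 carbon, 2 nitrogen, 2 oxygen; one five-membered aromatic ring with 3 hetero atoms), on a saturated chain carbon bound to an aromatic carbon and a saturated chain carbon). Two large measured steps, both beyond the scatter, bear on this change at the same place: an at least 44-fold higher number from compound 1 to compound 3 (1.65 log units; beyond the scatter) and an at least 14-fold higher number from compound 2 to compound 3 (1.14 log units; beyond the scatter) in the ring swaps. With that ring gone, compound 4 is expected to fall back toward compound 2 at 0.213 h in this assay as well. The expected step, large and downward, is estimated as an at least 10-fold lower number from compound 3 to compound 4 (1.00 log units; beyond the scatter) here. For compound 4 the half-life is estimated at 0.3 h (range 0.08 h to 1.1 h) in this read-out.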

Compound 4, half-life: < 0.0667 h
Compound 4 gave a limit, no number; the forecaster's own chance of this, stated with the estimate: 15%; middle value at least 4.4-fold (0.65 log units) from the limit.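

Swapping the ring for the open chain (isopropylcarbamoyl)methyl gives an at least 44-fold lower number from compound 3 to compound 4 (1.65 log units; beyond the scatter), and set against 4H-1,2,4-triazol-3-yl the same chain gives an at least 3.1-fold lower number from compound 2 to compound 4 (0.50 log units; beyond the scatter). So at this position, a ring with a far shorter half-life than the one in compound 3 still outlasts this chain. The result for compound 4 is a limit, the same one as for compound 1, so the step between them cannot be read: the limit of < 0.0667 h in this assay, at which 2 of the 4 values shown sit.

As far as these compounds go, whether a carboxylic acid or an amine on this chain would last longer stays open. So does how far the true half-life of compound 3 lies beyond its limit.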